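Nitro for chloro on two related cores, cytotoxicity notes

The compounds below may be only part of what the source reports. "The series", "measured", "known", "first", "only" and "open" are said of these compounds alone.

Compound 1 `COc1cc(/C=C/C(=O)/C=C/c2nc3cc(Cl)ccc3n2C)ccc1O` and compound 2 `COc1cc(/C=C/C(=O)/C=C/c2nc3cc([N+](=O)[O-])ccc3n2C)ccc1O` share one core; compound 3 `COc1ccc(/C=C/C(=O)/C=C/c2nc3cc(Cl)ccc3n2C)cc1O` has the same atoms joined differently, and the difference between the two cores is not broken down here. In a functional assay on MCF7 cells (Homo sapiens) for cytotoxicity, read by MTT assay, with a stated time of 48 h (a lower number here means a stronger inhibitor, a higher number a weaker inhibitor), compound 1 gives 4400 nM, compound 2 gives 3700 nM and compound 3 gives 3500 nM; all three values lie within the scatter of one another, so no order among them can be read. The change that recurs in the set is nitro in place of chloro on an aromatic carbon: on the core of compound 1 it produced a 1.2-fold lower number from compound 1 to compound 2 (0.08 log units; within the scatter). Compound 4 `COc1ccc(/C=C/C(=O)/C=C/c2nc3cc([N+](=O)[O-])ccc3n2C)cc1O` carries the same change on the core of compound 3, (nitro in place of chloro on an aromatic carbon), at a place described in the same words. For the measured compounds named here, because the one measured precedent a 1.2-fold lower number from compound 1 to compound 2 (0.08 log units; within the scatter) stays within the scatter, compound 4 is expected to sit close to its parent, with an expected step of a 1.2-fold lower number from compound 3 to compound 4 (0.08 log units; within the scatter) in this assay. The estimated value for compound 4 in this assay is 2900 nM, with 1500 nM to 6000 nM as the expected range. This rests on a single measured pair, nothing more.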

Compound 4, half-maximal inhibitory concentration: 4800 nM
Compound 4: middle estimate off by 1.7-fold (0.22 log units), on the low side; the range from low to high includes it.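

In this assay, nitro in place of chloro on the core of compound 3 gives a 1.4-fold higher number from compound 3 to compound 4 (0.14 log units; within the scatter), and the two measured instances of this change do not differ beyond what repeated measurement allows: the same change on two cores in this assay, a 1.2-fold lower number (0.08 log units; within the scatter) from compound 1 to compound 2 and a 1.4-fold higher number (0.14 log units; within the scatter) from compound 3 to compound 4, 1.6-fold (0.21 log units) apart, within the scatter of two such steps. With nitro held fixed, 3-hydroxy-4-methoxyphenyl in place of 4-hydroxy-3-methoxyphenyl gives a 1.3-fold higher number from compound 2 to compound 4 (0.11 log units; within the scatter), so the two cores cannot be told apart on this evidence either. The two pairs show that this change carries across these two cores without a step beyond the scatter, but they show no direction for it, and they do not show that it would behave the same way on any other core.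

The aromatic carbon carries only chloro or nitro in the compounds shown, so it stays open whether an amine or a carboxylic acid there would give a step beyond the scatter. Also open, on these data alone, is whether a longer chain on the oxygen in place of methoxy would shift the values on either core.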